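Moving a trifluoromethyl group: what to expect for cytotoxicity

This account rests on a few compounds, and the source may have more. Where it says the series, first, only, none or still open, it means among the compounds named here.

Compound 1 `COc1ccc([C@H]2CC(=O)N(c3cccc(O)c3)C2)cc1OC1CCCC1`: > 10000 nM
Compound 2 `COc1ccc([C@H]2CC(=O)N(c3cccc(C(F)(F)F)c3)C2)cc1OC1CCCC1`: > 10000 nM

Both entries are limits of the assay, not numbers. In a functional assay on HEK293 cells (Homo sapiens) for cytotoxicity (on this read-out lower numbers stand for higher toxicity in this test and higher numbers for lower toxicity in this test), compound 2 gives > 10000 nM, which is a limit, so it has no number of its own. It shares this position with compound 1: the limit of > 10000 nM in this assay, at which 2 of the 2 values shown sit.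

Compound 3 `COc1ccc([C@H]2CC(=O)N(c3ccc(C(F)(F)F)cc3)C2)cc1OC1CCCC1` keeps the core of compound 2 and changes only the group on an amide-type nitrogen in a ring, where 4-(trifluoromethyl)phenyl takes the place of 3-(trifluoromethyl)phenyl: 4-(trifluoromethyl)phenyl in place of 3-(trifluoromethyl)phenyl on an amide-type nitrogen in a ring.

For the measured compounds named here, the one measured step that bears on this is a step that the two limits leave unreadable from compound 1 to compound 2, with trifluoromethyl in place of hydroxy on an aromatic carbon. It offers no size to carry over, and it concerns a different change on the same aromatic ring. Neither measured compound gives a number in this assay, so no step beyond the scatter is expected, and the most likely result is another limit. The expected step is a step that the limit leaves unreadable from compound 2 to compound 3. For compound 3 the estimated value is 20000 nM, with an expected range from 8000 nM to 50000 nM.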

Compound 3, half-maximal cytotoxic concentration: > 10000 nM
Compound 3 was reported as a limit (the forecaster's own chance of this, stated with the estimate: 85%); the middle value lies beyond the limit too.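

Compound 3 is reported only as a limit in this assay, as are compound 1 and compound 2, so no step among these compounds can be read. The compounds shown leave open how far beyond the limit each one lies, and whether any group on the amide-type nitrogen would give a measurable value in this assay.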